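The source may hold more compounds than are shown below. What is called first, only, known or untested is meant among the compounds shown, and "the series" means these compounds.

Among the measured compounds shown here, the three compounds measured so far share one core. Compound 1 `COc1ccc(-c2cccc(C(=O)NCCN(C)C)c2)cc1S(=O)(=O)Nc1cccc(NCCNC(=O)c2cccc(C)c2)c1` carries a (2-(dimethylamino)ethyl)amino group on the carbonyl carbon; in a functional assay on CHO-RD-HGA16 cells for agonist activity at Orexin/Hypocretin receptor type 1 (Homo sapiens), read by fluorescence and calcium flux, with a stated time of 30 min (on this read-out higher numbers stand for an effect only at larger amounts of compound and lower numbers for an effect already at smaller amounts), compound 1 gives only a limit, > 10000 nM. Compound 2 `COc1ccc(-c2cccc(C(=O)N(C)c3ccccn3)c2)cc1S(=O)(=O)Nc1cccc(NCCNC(=O)c2cccc(C)c2)c1` has methyl(pyridin-2-yl)amino there, and in this assay compound 2 likewise gives a limit, > 10000 nM. Compound 3 `COc1ccc(-c2cccc(C(=O)N(C)Cc3ccccc3)c2)cc1S(=O)(=O)Nc1cccc(NCCNC(=O)c2cccc(C)c2)c1` bears benzyl(methyl)amino, and in this assay compound 3 also gives a limit, > 10000 nM. The steps a step that the two limits leave unreadable from compound 1 to compound 2, a step that the two limits leave unreadable from compound 1 to compound 3 and a step that the two limits leave unreadable from compound 2 to compound 3 are all unreadable because of the limit of > 10000 nM in this assay, at which 3 of the 3 values shown sit. Compound 4 `COc1ccc(-c2cccc(C(=O)N(C)Cc3cccnc3)c2)cc1S(=O)(=O)Nc1cccc(NCCNC(=O)c2cccc(C)c2)c1` differs from compound 3 by pyridin-3-yl in place of phenyl on a saturated chain carbon bound to an amide-type nitrogen. For the measured compounds named here, no measured step bears on this change with a readable size: every value so far is a limit. Compound 4 is therefore expected to stay at the limit, with an expected step that the limit leaves unreadable from compound 3 to compound 4. The estimate for compound 4 in this assay is 20000 nM, within 8000 nM to 50000 nM.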

Compound 4, half-maximal effective concentration: 460 nM
Estimate against measurement, compound 4: 43-fold (1.64 log units) above; measured number below the stated range.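

In this assay, among the compounds shown here, pyridin-3-yl in place of phenyl on a saturated chain carbon bound to an amide-type nitrogen gives an at least 21-fold lower number from compound 3 to compound 4 (1.33 log units; beyond the scatter), a step of readable size such as no earlier pair offered, and the swap only exchanges a ring carbon for a ring nitrogen. The other two pairs give an at least 21-fold lower number from compound 2 to compound 4 (1.33 log units; beyond the scatter) and an at least 21-fold lower number from compound 1 to compound 4 (1.33 log units; beyond the scatter), so the group on the carbonyl carbon can bring this read-out clear of the limit, and the pyridin-2-yl group of compound 2 does not show the same result. All three sizes are lower bounds only, because one compound of each pair sits at a limit: the limit of > 10000 nM in this assay, at which 3 of the 4 values shown sit.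

Going by these compounds, how a (pyridin-4-yl)methyl or a (pyrimidin-5-yl)methyl group would read at this place stays open. Also open, on these data alone, is the true size of each step, and whether the methyl on the amide-type nitrogen can give way to hydrogen.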